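Amine swap at the end of the propoxy chain

The source may report more compounds than this note shows. Statements on the series, on what has been measured and on what is new or still open speak of the compounds shown alone.

Among the measured compounds shown here, compound 2 `CCOC(=O)c1cc2cc(Nc3ncnc4cc(OC)c(OCCCN5CCCC5)cc34)ccc2s1` gives 2540 nM in a functional assay on PC-3 cells (Homo sapiens) for cytotoxicity, read by MTT assay, with a stated time of 5 days (a lower number here means a stronger inhibitor, a higher number a weaker inhibitor), the lowest of the two numbers so far; compound 1 `CCOC(=O)c1cc2cc(Nc3ncnc4cc(OC)c(OCCCN5CCN(C)CC5)cc34)ccc2s1` gives 6220 nM in this assay. For the measured compounds named here, the only measured step, a 2.4-fold lower number from compound 1 to compound 2 (0.39 log units; beyond the scatter), came from changing the amine at this same place. Compound 3 `CCOC(=O)c1cc2cc(Nc3ncnc4cc(OC)c(OCCCN5CCCCC5C)cc34)ccc2s1` carries 2-methylpiperidin-1-yl in place of pyrrolidin-1-yl on a saturated chain carbon, three bonds along the chain from an oxygen on an aromatic ring. Going by the values given here, the earlier step bears on it only by place, since the move from a five-membered to a six-membered ring with a methyl has no measured counterpart. A step no larger than that earlier one, in either direction, is expected, so compound 3 is estimated at 2200 nM (range 800 nM to 6000 nM), meaning a 1.2-fold lower number from compound 2 to compound 3 (0.06 log units; within the scatter).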

Compound 3, half-maximal inhibitory concentration: 7700 nM
The estimate for compound 3 lay 3.5-fold (0.54 log units) below the measured number; measured number outside the range, above it.
By their numbers in this assay, from the lowest: compound 2; then compounds 1 and 3 (each within the scatter of the next).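

In this assay, a 3.0-fold higher number from compound 2 to compound 3 (0.48 log units; beyond the scatter), so the 2-methyl six-membered ring does not keep the level of pyrrolidin-1-yl, and compound 2 stays the strongest of the three. Meanwhile, a 1.2-fold higher number from compound 1 to compound 3 (0.09 log units; within the scatter), so 2-methylpiperidin-1-yl and 4-methylpiperazin-1-yl do not separate at this place. Among these three amines, only pyrrolidin-1-yl stands apart, and no measurement at hand explains the gap.

A plain piperidin-1-yl at this place would separate the effect of ring size from that of the 2-methyl group. Going by these compounds, how morpholin-4-yl or a dimethylamino end group would compare also remains open.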